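The source may hold more compounds than are shown below. What is called first, only, known or untested is meant among the compounds shown, and "the series" means these compounds.

Of the compounds shown here, three built on the same core have been tested in a functional assay on PC-12 cells (Rattus norvegicus) for cytotoxicity, read by MTT assay, with stated times of 2 h and 24 h, tested at 1 uM; on this read-out higher numbers stand for a stronger effect at the one concentration tested and lower numbers for a weaker effect. Compound 1, `Oc1cc(C(F)(F)F)ccc1-c1nc(-c2ccccc2O)n(-c2ccc(Br)cc2)n1`, gives 69.4%. Compound 2, `N#Cc1ccc(-n2nc(-c3ccc(C(F)(F)F)cc3O)nc2-c2ccccc2O)cc1`, gives 66.6%, and compound 3, `COc1ccccc1-n1nc(-c2ccc(C(F)(F)F)cc2O)nc1-c1ccccc1O`, gives 70.7%. On these three numbers compound 1 stands second highest, though every gap is small: to its nearest neighbour the step is a number 1.3 percentage points higher from compound 1 to compound 3 (within the scatter), and to the furthest it is a number 2.8 percentage points lower from compound 1 to compound 2 (within the scatter). The remaining pair shows a number 4.1 percentage points higher from compound 2 to compound 3 (within the scatter).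

The next compound, compound 4, is `Cc1ccc(-n2nc(-c3ccc(C(F)(F)F)cc3O)nc2-c2ccccc2O)c(C)c1`. Compared with compound 1 the difference is 2,4-dimethylphenyl in place of 4-bromophenyl on an aromatic nitrogen.

Two of the measured steps involve the same place, the group on the aromatic nitrogen: the exchange of 4-bromophenyl for 2-methoxyphenyl, a number 1.3 percentage points higher from compound 1 to compound 3 (within the scatter), and the exchange of 4-cyanophenyl for 2-methoxyphenyl, a number 4.1 percentage points higher from compound 2 to compound 3 (within the scatter). The third step, a number 2.8 percentage points lower from compound 1 to compound 2 (within the scatter), changes a substituent on the group at that same nitrogen. All three stay within the scatter of repeated measurements, so a swap to 2,4-dimethylphenyl at this nitrogen is expected to give no step beyond the scatter in this assay, amounting to an estimated a number 0.4 percentage points lower from compound 1 to compound 4 (within the scatter). Compound 4 is therefore estimated at 69%, expected to fall between 58% and 80%.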

Compound 4, a percentage reported as activity, at one concentration (the size of the read-out at that concentration, not a potency): 73.7%
Beside the measured number, compound 4's estimate is 4.7 percentage points below it; the measured number falls inside the stated range.
By their numbers in this assay, from the lowest: compounds 2, 1, 3 and 4 (each within the scatter of the next).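

The four groups now seen on this aromatic nitrogen include 2,4-dimethylphenyl, the first whose eight heavy atoms are all carbon, with no bromine, nitrile or methoxy group on the phenyl ring. This change does not move the result in this assay beyond the scatter, with a number 4.3 percentage points higher from compound 1 to compound 4 (within the scatter) against 4-bromophenyl, a number 3 percentage points higher from compound 3 to compound 4 (within the scatter) against 2-methoxyphenyl and a number 7.1 percentage points higher from compound 2 to compound 4 (within the scatter) against 4-cyanophenyl, so among these four compounds every substituted phenyl group tried at this position gives a result within the scatter of the others. No measurement shown here offers an explanation for how closely these numbers agree.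

On these data alone, all four compounds keep a phenyl ring on this nitrogen, so it remains open whether a saturated ring such as cyclohexyl, a longer alkyl chain, or a phenyl ring bearing an amine or a carboxylic acid would give a step beyond the scatter. The trifluoromethyl group and the two hydroxyl groups are also the same throughout, which leaves their part in the result open, and a single concentration says nothing about potency.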